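The source may hold more compounds than are shown below. What is called first, only, known or untested is meant among the compounds shown, and "the series" means these compounds.

Working notes on the series. Compound 2 `Cc1c(Cl)cccc1C(=O)NC(CCN(C)C)c1ccc(Cl)cc1` gives 1740 nM in an assay on NIH3T3 cells with Urotensin-2 receptor (Homo sapiens) as the target; a higher number here means that more compound is needed for the effect, a lower number that less compound is needed. Among the three compounds measured it gives the second highest number: compound 3 `COc1ccc(NC(=O)OC(CCN(C)C)c2ccc(Cl)cc2)cc1` gives 1660 nM in this assay, which lies within the scatter of compound 2, while compound 1 `COc1cccc(C(=O)NC(CCN(C)C)c2ccc(Cl)cc2)c1C` gives 4270 nM, and the step from compound 1 to compound 2 is a 2.5-fold lower number from compound 1 to compound 2 (0.39 log units; beyond the scatter), a change of chloro in place of methoxy on an aromatic carbon.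

Compound 4 `CN(C)CCC(NC(=O)NCc1ccccc1)c1ccc(Cl)cc1` is the next compound, with the change (benzylamino in place of 3-chloro-2-methylphenyl on a carbonyl carbon). Among the measured compounds shown here, no measured step touches this part of the molecule: the only step with a number, the one from compound 1 to compound 2, concerns a substituent on the aromatic ring that is now exchanged entirely, and compound 3, which carries a different group on the carbonyl carbon, is not a single-place neighbour of compound 2. For the measured compounds named here, its value and that of compound 2 are within the scatter of each other, which is the only hint that the group on the carbonyl carbon can be altered without a large shift. A step of no more than the usual scatter is therefore expected from compound 2 to compound 4, a 1.4-fold higher number from compound 2 to compound 4 (0.16 log units; within the scatter), in either direction. Compound 4 is estimated at 2500 nM, with a range from 700 nM to 9000 nM.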

Compound 4, half-maximal effective concentration: 2000 nM
Compound 4: the middle estimate sits 1.3-fold (0.10 log units) above what was measured; the range from low to high includes it.
By their numbers in this assay, from the lowest: compounds 3, 2 and 4 (each within the scatter of the next); then compound 1.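

In this assay, the exchange on the carbonyl carbon gives a 1.1-fold higher number from compound 2 to compound 4 (0.06 log units; within the scatter), so this first single-place step at the position stays inside the scatter, even though the whole aromatic group attached there is replaced. The 3-chloro-2-methylphenyl group gives way to benzylamino, which brings in a nitrogen and one hydrogen-bond donor and loses the chlorine, and no shift can be told from the scatter, whereas the earlier step on the aromatic ring, a 2.5-fold lower number from compound 1 to compound 2 (0.39 log units; beyond the scatter), lies beyond it. No supporting data are at hand to say why this exchange leaves the number within the scatter.

Still open, on these data alone, is whether the benzylamino group tolerates further change at the same carbonyl carbon, for instance a phenethylamino group with its longer chain, or a cyclohexylamino group with a saturated ring in place of the aromatic one. Also open, as far as these compounds go, is whether a chloro or methoxy group on the ring of benzylamino would give a step of the kind seen on the aromatic ring of compound 1 and compound 2.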